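From Pyridin-3-yl to Pyrimidin-2-yl: Compound 4 Awaits Measurement

The compounds below may be only part of what the source reports. "The series", "measured", "known", "first", "only" and "open" are said of these compounds alone.

Measured so far:
compound 1 `Nc1ccccc1NC(=O)c1ccc(CSC(=S)N2CCN(Cc3ccccn3)CC2)cc1` gives 82.4% in a functional assay on A-375 cells (Homo sapiens) for antiproliferative activity, read by CCK-8 assay, with a stated time of 72 h, tested at 8 uM; a higher number here means a stronger effect of the compound at the concentration tested, a lower number a weaker effect;
compound 2 `Nc1ccccc1NC(=O)c1ccc(CSC(=S)N2CCN(C3CCCCC3)CC2)cc1` gives 89.9%;
compound 3 `Nc1ccccc1NC(=O)c1ccc(CSC(=S)N2CCN(c3cccnc3)CC2)cc1` gives 88.8%.

Compound 3 stands second highest of the three numbers. Its nearest neighbour on the numbers is reached by the step of a number 1.1 percentage points lower from compound 2 to compound 3 (within the scatter), its furthest by a number 6.4 percentage points higher from compound 1 to compound 3 (within the scatter). Compound 4 `Nc1ccccc1NC(=O)c1ccc(CSC(=S)N2CCN(c3ncccn3)CC2)cc1` differs from compound 3 in one place: pyrimidin-2-yl in place of pyridin-3-yl on an amine nitrogen in a ring. All three measured steps alter the same amine nitrogen in a ring, and each stayed within the scatter: a number 7.5 percentage points higher from compound 1 to compound 2 (within the scatter), a number 6.4 percentage points higher from compound 1 to compound 3 (within the scatter), a number 1.1 percentage points lower from compound 2 to compound 3 (within the scatter). Within the data shown here, none of them exchanges one six-membered aromatic ring with hetero atoms for another, so no step bears on this change directly. In this assay compound 4 is therefore expected to give 86%, between 72% and 95%. The expected step is a number 2.8 percentage points lower from compound 3 to compound 4 (within the scatter), not beyond the scatter.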

Compound 4, a percentage reported as inhibition, at one concentration (the size of the read-out at that concentration, not a potency): 67.9%
Compound 4: the middle estimate sits 18.1 percentage points above what was measured; the whole stated range lies above it.
By their numbers in this assay, from the lowest: compound 4; then compounds 1, 3 and 2 (each within the scatter of the next).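

In this assay, the earlier exchanges on this amine nitrogen in a ring all stayed within the scatter, whereas pyrimidin-2-yl gives steps beyond it: a number 20.9 percentage points lower from compound 3 to compound 4 (beyond the scatter), a number 22 percentage points lower from compound 2 to compound 4 (beyond the scatter) and a number 14.5 percentage points lower from compound 1 to compound 4 (beyond the scatter). The change from pyridin-3-yl keeps the six heavy atoms and the single aromatic ring, yet swapping one ring carbon for a second nitrogen is enough for this lower number. Nothing available here accounts for the drop. The compounds shown leave open whether a phenyl or a pyridin-2-yl group on this nitrogen would stand with compound 3 or with compound 4.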